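One Added Hydroxy on a Level Pair

The compounds below may be only part of what the source reports. "The series", "measured", "known", "first", "only" and "open" are said of these compounds alone.

In a functional assay on DU-145 cells (Homo sapiens) for inhibition, read by trypan blue exclusion, with a stated time of 96 h (a lower number here means a stronger inhibitor of growth, a higher number a weaker inhibitor of growth), compound 1 `O=C(/C(=C\c1ccc(O)cc1O)SCc1cccc(Cl)c1)c1ccc(Br)cc1` gives 50000 nM. Compound 2 `O=C(/C(=C\c1ccccc1O)Sc1ccccc1Br)c1ccc(Br)cc1` gives 50000 nM, so it stands level with compound 1, and this readout cannot separate the two.

Compound 3 `O=C(/C(=C\c1ccc(O)cc1O)Sc1ccccc1Br)c1ccc(Br)cc1` has not yet been measured. It differs from compound 2 in one place, hydroxy in place of hydrogen on an aromatic carbon: hydroxy replaces hydrogen on an aromatic carbon, turning 2-hydroxyphenyl into 2,4-dihydroxyphenyl. Within the data shown here, no measured pair shows this change alone, so the data give no direct size for it.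

The only indirect clue is that compound 1 also carries a 2,4-dihydroxyphenyl group and gives 50000 nM. That single compound offers no sign of strong growth inhibition with this group. No step beyond the usual scatter is therefore expected in this assay, with at most a slight lean toward stronger inhibition. The expected change is a 1.4-fold lower number from compound 2 to compound 3 (0.15 log units; within the scatter). For compound 3 the estimated value is 35000 nM, with an expected range from 8000 nM to 80000 nM.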

Compound 3, concentration for 50% growth inhibition: 50000 nM
Beside the measured number, compound 3's estimate is 1.4-fold (0.15 log units) below it, and the stated range covers the measured number.
By their numbers in this assay, from the lowest: compounds 1, 2 and 3 (each within the scatter of the next).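

In this assay, among these compounds, the hydroxy group that turns 2-hydroxyphenyl into 2,4-dihydroxyphenyl now has a direct reading of no change at the digits printed from compound 2 to compound 3 (within the scatter) and so, on this one pair, adding it gives no step the assay can detect. Compound 3 also completes a second comparison, in which the group on the sulfur is exchanged, and that reads no change at the digits printed from compound 1 to compound 3 (within the scatter) even though 2-bromophenyl and 3-chlorobenzyl are quite different groups, so with 2,4-dihydroxyphenyl in place this assay does not separate them. Nothing on hand offers an explanation for either flat step.

The compounds shown leave open whether this ring position can affect growth inhibition at all, since a single added hydroxy is the only change read there, and a methoxy group, an amine or a carboxylic acid in its place might or might not behave the same way. They also leave open whether a longer chain on the sulfur, or a ring without bromine, would move the number away from the level shared by all three compounds.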